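Ester chain lengthened with a phenoxy end

The compounds below may be only part of what the source reports. "The series", "measured", "known", "first", "only" and "open" are said of these compounds alone.

Compound 1, `O=C(CCCCCc1ccccc1)OCC1COCCOCCOCCOCCOCCO1`: 64000 nM
Compound 2, `O=C(CCCCOc1ccccc1)OCC1COCCOCCOCCOCCOCCO1`: > 100000 nM, a limit of the assay, not a number.
Compound 3, `CC(=O)OCC1COCCOCCOCCOCCOCCO1`: > 100000 nM, again a limit of the assay.

Among the compounds with values here, in a functional assay on HBL-100 cells (Homo sapiens) for inhibition, read by sulforhodamine B assay, with a stated time of 48 h (on this read-out higher numbers stand for weaker inhibition of growth and lower numbers for stronger inhibition of growth), compound 1 holds the only number measured; the other two values are limits (the limit of > 100000 nM in this assay, at which 2 of the 3 values shown sit). Compound 4, `O=C(CCCCCCCCCCOc1ccccc1)OCC1COCCOCCOCCOCCOCCO1`, differs from compound 1 by 5-phenoxypentyl in place of phenyl on a saturated chain carbon, five bonds along the chain from a carbonyl carbon. Within the data shown here, two measured steps bear on this: an at least 1.5-fold higher number from compound 1 to compound 2 (0.19 log units; that floor lies within the scatter) and an at least 1.5-fold higher number from compound 1 to compound 3 (0.19 log units; that floor lies within the scatter). Both are floors within the scatter, so neither settles a direction. Among the measured compounds shown here, a phenoxy end gave no gain in compound 2, and compound 1 stays the only measured number, so compound 4 is expected to sit near it, with a step of a 1.3-fold lower number from compound 1 to compound 4 (0.11 log units; within the scatter). The estimate for compound 4 is 50000 nM, between 15000 nM and 150000 nM.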

Compound 4, concentration for 50% growth inhibition: 20000 nM
The estimate for compound 4 lay 2.5-fold (0.40 log units) above the measured number; low and high end bracket the measured number.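

Replacing phenyl with 5-phenoxypentyl, five bonds along the chain from a carbonyl carbon, gives a 3.2-fold lower number from compound 1 to compound 4 (0.51 log units; beyond the scatter) in this assay. Within the data shown here, this is the first step that can be read beyond the scatter, and it shows that growth inhibition at this position can strengthen with a phenoxy end in place. The earlier steps cannot show this, as their sizes cannot be read from limits: the limit of > 100000 nM in this assay, at which 2 of the 4 values shown sit.

This change adds chain length and an oxygen together, and the two effects cannot be separated here. From the compounds shown here alone, what a chain of the same length ending in plain phenyl, or in an amine, would give stays open.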